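A few compounds are considered here, and "the series" means these few. Any claim that something is new, unique, unknown or untested is made for them only; others in the source may bear on it.

Measured compounds:

Compound 1 `O=C(Nc1cccc(-n2cc(-c3ccncc3)c(-c3ccc(Cl)c(O)c3)n2)c1)Nc1cc(C(F)(F)F)cc(C(F)(F)F)c1`: in a functional assay on BT-549 cells (Homo sapiens) for inhibition, read by sulforhodamine B assay, with a stated time of 48 h (on this read-out higher numbers stand for lower toxicity in this test and lower numbers for higher toxicity in this test), compound 1 gives 4110 nM.
Compound 2 `COc1cc(-c2nn(-c3cccc(NC(=O)Nc4ccc(Cl)c(C(F)(F)F)c4)c3)cc2-c2ccncc2)ccc1Cl`: in this assay compound 2 gives > 32500 nM, which is a limit of the assay.
Compound 3 `COc1cc(-c2nn(-c3cccc(NC(=O)c4ccccc4)c3)cc2-c2ccncc2)ccc1Cl`: in this assay compound 3 gives > 100000 nM, which is also a limit of the assay.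

Among the compounds with values here, compound 1 therefore stands as the only measured number in this assay; the other two results are limits the limit of > 32500 nM in this assay, at which 1 of the 3 values shown sits (the limit of > 100000 nM in this assay, at which 1 of the 3 values shown sits). Within the data shown here, the one measured step, a step that the two limits leave unreadable from compound 2 to compound 3, cannot be sized and concerns a different part of the molecule.

Compound 4 `O=C(Nc1cccc(-n2cc(-c3ccncc3)c(-c3ccc(Cl)c(O)c3)n2)c1)Nc1cccc(C(F)(F)F)c1` is derived from compound 1 by one change: hydrogen in place of trifluoromethyl on an aromatic carbon. Among the measured compounds shown here, no measured step in this set touches that position, so the expectation rests only on the small size of the change. Compound 4 is expected to stay close to compound 1, with a step of a 1.5-fold higher number from compound 1 to compound 4 (0.16 log units; within the scatter) that may fall within the usual scatter. The estimate for compound 4 in this assay is 6000 nM, within a range from 2000 nM to 20000 nM.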

Compound 4, concentration lethal to 50% of the cells: > 32500 nM
Compound 4 gave a limit, no number; the forecaster's own chance of this, stated with the estimate: 10%; at least 5.4-fold (0.73 log units) between middle value and limit.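

In this assay, within the data shown here, hydrogen in place of trifluoromethyl on this aromatic carbon gives an at least 7.9-fold higher number from compound 1 to compound 4 (0.89 log units; beyond the scatter), so this one position, which no earlier step touched, clearly affects toxicity in this test, and losing the group lowers it. Compound 4 gives > 32500 nM, which is a limit of the assay and not a number. The full size of the step therefore stays unknown, because compound 4 rests at a limit and its true value could lie well beyond it: the limit of > 32500 nM in this assay, at which 2 of the 4 values shown sit.

From the compounds shown here alone, it remains open whether the trifluoromethyl group itself is needed here, or whether a methyl group or an amine on the same aromatic carbon would keep the number near that of compound 1. The compounds shown also leave open whether the same change would have a similar effect on a core carrying a different substituent.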